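The source may hold more compounds than are shown below. What is called first, only, known or untested is meant among the compounds shown, and "the series" means these compounds.

In a functional assay on MOLM-13 cells (Homo sapiens) for antiproliferative activity (a higher number here means a weaker inhibitor, a lower number a stronger inhibitor), compound 1 `Cc1c(-c2ccc(-c3ccccc3F)cc2)nc2ccc(F)cc2c1CO` gives 700 nM and compound 2 `COC(=O)NC(=O)c1c(C)c(-c2ccc(-c3ccccc3F)cc2)nc2ccc(F)cc12` gives 403 nM. Among the compounds with values here, these are the only two numbers so far, and the step is a 1.7-fold lower number from compound 1 to compound 2 (0.24 log units; within the scatter). Compound 3 `Cc1c(-c2ccc(-c3ccccc3F)cc2)nc2ccc(F)cc2c1C(=O)N(C)O` differs from compound 2 by hydroxy(methyl)amino in place of (methoxycarbonyl)amino on a carbonyl carbon, with hydroxy(methyl)amino in place of (methoxycarbonyl)amino on a carbonyl carbon. Within the data shown here, only that single measured step bears on this change, and it stays within the scatter, so no shift beyond the scatter is expected in either direction. The expected change is a 1.2-fold higher number from compound 2 to compound 3 (0.09 log units; within the scatter). For compound 3 the estimated value is 500 nM, with a range of 130 nM to 2000 nM.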

Compound 3, half-maximal inhibitory concentration: 5100 nM
Compound 3: middle estimate off by 10-fold (1.01 log units), on the low side, outside the stated range (above it).
By their numbers in this assay, from the lowest: compounds 2 and 1 (each within the scatter of the next); then compound 3.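

In this assay this aromatic carbon proves sensitive to its substituent: hydroxy(methyl)carbamoyl gives a 13-fold higher number from compound 2 to compound 3 (1.10 log units; beyond the scatter) and a 7.3-fold higher number from compound 1 to compound 3 (0.86 log units; beyond the scatter) even though hydroxymethyl and (methoxycarbonyl)carbamoyl had stayed within the scatter of each other. A carbonyl carbon at this place therefore does not by itself preserve the activity, as compound 2 and compound 3 both carry one and still differ beyond the scatter. Nothing available explains this drop.

Still open, on these data alone, is whether the drop follows the hydroxy or the methyl of the new group, which a methylamino or hydroxyamino group on the same carbonyl carbon would separate. A carboxylic acid at this place also remains to be placed against compound 2 and compound 3.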